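Compound 1 and its counterpart without drawn configuration

A few compounds are considered here, and "the series" means these few. Any claim that something is new, unique, unknown or untested is made for them only; others in the source may bear on it.

Compound 1 (`O=[N+]([O-])c1cn2c(n1)[S@@+]([O-])C[C@@H](OCc1ccc(OC(F)(F)F)cc1)C2`) is the reference point here. In an ADME assay on L929 cells (Mus musculus) for cytotoxicity (on this read-out lower numbers stand for stronger inhibition and higher numbers for weaker inhibition), compound 1 gives > 10 ug/mL, which is a limit and not a number. Compound 2 (`CC1(COCc2ccc(OCc3ccccc3)cc2)Cn2cc([N+](=O)[O-])nc2S1`) gives > 10 ug/mL, also a limit. Compound 3 (`O=[N+]([O-])c1cn2c(n1)OCC(COc1ccc(-c3ccc(C(F)(F)F)cc3)nc1)C2`) gives > 10 ug/mL, again a limit. The series therefore stands at the limit of > 10 ug/mL in this assay, at which 3 of the 3 values shown sit.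

Compound 4 (`O=[N+]([O-])c1cn2c(n1)[S+]([O-])CC(OCc1ccc(OC(F)(F)F)cc1)C2`) relates to compound 1 as follows: the two compounds have the same atoms and bonds; at least one stereo element is drawn with a configuration in one of them and without one in the other: 2 of 2 stereo elements differ; a stereocentre at a sulfur is drawn S in compound 1 and without a configuration in compound 4; a stereocentre at a saturated ring carbon is drawn S in compound 1 and without a configuration in compound 4. No measured step sizes this change, so no step beyond the scatter is expected in this assay, and no direction is favoured. The expectation starts from compound 1 and its limit of > 10 ug/mL. The estimated step that the limit leaves unreadable from compound 1 to compound 4 stays within the scatter. For compound 4 the expected value is 15 ug/mL, with an estimated range from 8 ug/mL to 40 ug/mL.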

Compound 4, half-maximal inhibitory concentration: > 10 ug/mL
Compound 4 gave a limit, no number (the forecaster's own chance of this, stated with the estimate: 80%); the middle value lies beyond the limit too.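

For the compounds shown here, compound 1 and compound 4 both sit at limits in this assay, so no step between them can be read. The compounds shown leave open whether the drawn configuration changes cytotoxicity at all, since every value rests at one limit: the limit of > 10 ug/mL in this assay, at which 4 of the 4 values shown sit.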